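Three inactive analogues and a chloro shift

The source may hold more compounds than are shown below. What is called first, only, known or untested is meant among the compounds shown, and "the series" means these compounds.

Compound 1 `O=C1COC(c2ccc(NS(=O)(=O)c3cccc(Cl)c3)cc2)=NN1` — in an assay on cells for inhibition of Amine oxidase [flavin-containing] A (Homo sapiens), read by Amplex Red, with a stated time of 30 min (on this read-out lower numbers stand for stronger inhibition and higher numbers for weaker inhibition), compound 1 gives > 100000 nM, a limit of the assay.
Compound 2 `O=C1COC(c2ccc(NCc3cccc(Cl)c3)cc2)=NN1` — in this assay compound 2 gives > 100000 nM, again a limit.
Compound 3 `O=C1COC(c2ccc(/N=N/c3cccc(Cl)c3)cc2)=NN1` — in this assay compound 3 gives > 100000 nM, also a limit.

Compound 3 therefore stands at the limit of this assay rather than at a measured number. For the measured compounds named here, its two companions do the same, so all three values shown sit at the limit of > 100000 nM in this assay, at which 3 of the 3 values shown sit, and no step between measured compounds can be computed.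

Compound 4 `O=C1COC(c2ccc(/N=N/c3ccc(Cl)cc3)cc2)=NN1` differs from compound 3 in one place: 4-chlorophenyl in place of 3-chlorophenyl on a double-bonded nitrogen. Going by the values given here, with no measured step to draw on and every value resting at a limit, nothing here suggests that moving the chlorine within the pendant ring would pull the potency into the measurable range, so the expected step is none beyond the scatter. Compound 4 is expected to give about 150000 nM in this assay, within roughly 30000 nM to 1000000 nM, most probably again as a limit. That estimate corresponds to an expected step that the limit leaves unreadable from compound 3 to compound 4.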

Compound 4, half-maximal inhibitory concentration: > 100000 nM
Compound 4: no number, only a limit; the forecaster's own chance of this, stated with the estimate: 85%; the middle value is on the limit's open side.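

No step can be read between compound 3 and compound 4, as both rest at a limit of the assay: the limit of > 100000 nM in this assay, at which 4 of the 4 values shown sit.

The compounds shown leave open whether any change to the shared core or the chlorophenyl group would give a measurable value in this assay.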